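Notes on Ring-Nitrogen Aryl Changes in a Shared Core

This account rests on a few compounds, and the source may have more. Where it says the series, first, only, none or still open, it means among the compounds named here.

Of the compounds shown here, three have been measured in a functional assay on HOS-TE85 cells (Homo sapiens) for inhibition, read by CCK-8 assay, with a stated time of 72 h; a lower number here means a stronger inhibitor, a higher number a weaker inhibitor. Compound 1 `O=C(NCCCCc1ccccc1)c1cccc(C2SCC(=O)N2c2cccc(-c3c[nH]nn3)c2)c1` gives 110 nM in this assay. Compound 2 `COc1ccc(F)cc1N1C(=O)CSC1c1cccc(C(=O)NCCCCn2cccn2)c1` gives 97.3 nM in this assay, and compound 3 `CCOc1ccccc1N1C(=O)C(C)SC1c1cccc(C(=O)NCCCCc2ccccc2)c1` gives 71.6 nM in this assay. Compound 2 stands second highest of the three numbers; its nearest neighbour is compound 1, a gap within the usual scatter, and its furthest is compound 3, also within the scatter. Going by the values given here, no pair among the three differs in one place only, so no single step can be read off; the three numbers simply lie close together while the group on the amide-type nitrogen in the ring varies.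

The next compound, compound 4 `O=C(NCCCCn1cccn1)c1cccc(C2SCC(=O)N2c2cc(Br)ccn2)c1`, is not yet measured. It differs from compound 2 as follows: 4-bromopyridin-2-yl in place of 5-fluoro-2-methoxyphenyl on an amide-type nitrogen in a ring. Both the group that leaves and the group that enters are single six-membered aromatic rings.

Because the three measured compounds, with different groups at this place, all fall close to one another, the expected step in this assay is a 1.1-fold higher number from compound 2 to compound 4 (0.05 log units; within the scatter), none beyond the scatter. For compound 4 the estimated value in this assay is 110 nM, with a range from 50 nM to 300 nM.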

Compound 4, half-maximal inhibitory concentration: 105 nM
For compound 4 the middle estimate is 1.0-fold (0.02 log units) above the measured one, and the stated range covers the measured number.
By their numbers in this assay, from the lowest: compounds 3, 2, 4 and 1 (each within the scatter of the next).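

In this assay, going by these compounds alone, the exchange of 5-fluoro-2-methoxyphenyl for 4-bromopyridin-2-yl on the amide-type nitrogen in the ring gives a 1.1-fold higher number from compound 2 to compound 4 (0.03 log units; within the scatter) and provides the first reading at this position with the rest of the molecule held constant. The earlier compounds shown here could only be set side by side, whereas this single-place step shows that a carbon-only aromatic ring bearing fluoro and methoxy groups and an aromatic ring with one hetero atom bearing bromine are not separated in this assay, even though the entering group has fewer heavy atoms. No measurement at hand accounts for this result.

Both groups in this step are single six-membered aromatic rings, so the step says nothing about a saturated ring such as cyclohexyl at this position, or about an aromatic ring bearing a primary amine or a carboxylic acid. It also leaves open whether a step beyond the scatter can be found at this position, and whether the same exchange would read alike with the phenylbutyl amide chain of compound 3 in place of the pyrazolylbutyl chain.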